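The compounds below may be only part of what the source reports. "The series", "measured", "known", "first", "only" and "open" are said of these compounds alone.

Working notes, series of carbamates on a shared core.

Compound 3 `CC1(OC(=O)N2CCC(O[C@H]3CC[C@H](Oc4cnc(S(C)(=O)=O)cn4)CC3)CC2)CC1` gives 118% in a functional assay on isolated protein for agonist activity at Glucose-dependent insulinotropic receptor (Homo sapiens), read by HTRF and cAMP accumulation; on this read-out lower numbers stand for smaller maximal responses and higher numbers for larger maximal responses. Among the three measured compounds this is the highest of the numbers, yet the margins are small: compound 1 `CC(C)(C)OC(=O)N1CCC(O[C@H]2CC[C@H](Oc3cnc(S(C)(=O)=O)cn3)CC2)CC1` gives 110% in this assay, and compound 2 `CC(C)OC(=O)N1CCC(O[C@H]2CC[C@H](Oc3cnc(S(C)(=O)=O)cn3)CC2)CC1` gives 110%. The two steps leading to compound 3 are a number 8 percentage points higher from compound 1 to compound 3 (within the scatter) and a number 8 percentage points higher from compound 2 to compound 3 (within the scatter); the step between the other pair is no change at the digits printed from compound 1 to compound 2 (within the scatter). All three measured compounds therefore sit in one band, and compound 3 cannot be called the most active on this evidence.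

Compound 4 `C[C@H](CF)OC(=O)N1CCC(O[C@H]2CC[C@H](Oc3cnc(S(C)(=O)=O)cn3)CC2)CC1` is the next point in the same position. The change from compound 3 is 1-(fluoromethyl)ethyl in place of 1-methylcyclopropyl on an oxygen next to a carbonyl group. Going by the values given here, every measured step so far concerns the same position, the group on an oxygen next to a carbonyl group, and each of those steps stayed within the scatter: tert-butyl to isopropyl, tert-butyl to 1-methylcyclopropyl, isopropyl to 1-methylcyclopropyl. Nothing in the data separates ring from chain at this position, and no fluorine-bearing group has been measured, so the reach of the comparison is limited to that band. On that basis the expected step in this assay is a number 6 percentage points lower from compound 3 to compound 4 (within the scatter), that is, no change beyond the scatter. Compound 4 is estimated at 112%, with a range from 98% to 126%.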

Compound 4, largest response reached (Emax), in percent of the reference or control that the assay uses: 108%
The estimate for compound 4 lay 4 percentage points above the measured number; measured number inside the range.
By their numbers in this assay, from the lowest: compounds 4, 1, 2 and 3 (each within the scatter of the next).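

In this assay, a fluorine-bearing group on an oxygen next to a carbonyl group now joins the earlier carbamates in one band: fluoro in place of hydrogen on the chain gives a number 2 percentage points lower from compound 2 to compound 4 (within the scatter) and 1-(fluoromethyl)ethyl in place of tert-butyl gives a number 2 percentage points lower from compound 1 to compound 4 (within the scatter) as the second reading of the same band. The swap of 1-methylcyclopropyl for 1-(fluoromethyl)ethyl, which removes the ring and brings in a defined stereocentre at an unchanged count of four heavy atoms, gives a number 10 percentage points lower from compound 3 to compound 4 (within the scatter) and so leaves ring and fluorinated chain unseparated at this position. No data on hand bear on why these steps stay this small.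

The compounds shown leave open whether any group on this oxygen moves the maximal response out of the band, for instance a 2,2,2-trifluoroethyl group, a longer chain such as n-hexyl, or a chain ending in a carboxylic acid or an amine. They also leave open how the opposite configuration of the 1-(fluoromethyl)ethyl group reads, and what a change anywhere else on the shared core does to this number.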